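Sulfonamide nitrogen substituent and whole-animal potency

This account rests on a few compounds, and the source may have more. Where it says the series, first, only, none or still open, it means among the compounds named here.

Compound 1 `CCNS(=O)(=O)c1ccc2c(c1)C(n1ccccc1=O)=CC(C)(C)O2` is the reference point of the series. Among the measured compounds shown here, in a functional assay with Rattus norvegicus as the target (on this read-out lower numbers stand for an effect already at smaller amounts and higher numbers for an effect only at larger amounts of compound), compound 1 gives 56.2 nM, the lowest of the two numbers measured so far. Compound 2 `CC1(C)C=C(n2ccccc2=O)c2cc(S(=O)(=O)Nc3ccc(C#N)cc3)ccc2O1` carries an aryl group in place of the ethyl on the sulfonamide nitrogen; in this assay compound 2 gives 263 nM, a step of a 4.7-fold higher number from compound 1 to compound 2 (0.67 log units; beyond the scatter). Compound 3 `CC1(C)C=C(n2ccccc2=O)c2cc(S(=O)(=O)Nc3ccc([N+](=O)[O-])cc3)ccc2O1` differs from compound 1 in one place: 4-nitrophenyl in place of ethyl on a sulfonamide nitrogen. For the measured compounds named here, the only measured step that bears on this change is the move from compound 1 to compound 2, which exchanged the same ethyl for a 4-cyanophenyl and gave a 4.7-fold higher number from compound 1 to compound 2 (0.67 log units; beyond the scatter). A 4-nitrophenyl in the same place is expected to act in the same direction, so a modest rise in the number beyond the scatter is expected, a 4.4-fold higher number from compound 1 to compound 3 (0.65 log units; beyond the scatter). For compound 3 in this assay the estimate is 250 nM, within 90 nM to 700 nM.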

Compound 3, half-maximal effective concentration: 2090 nM
The estimate for compound 3 lay 8.4-fold (0.92 log units) below the measured number; measured number above the stated range.
By their numbers in this assay, from the lowest: compound 1; then compound 2; then compound 3.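

In this assay, 4-nitrophenyl in place of ethyl on the sulfonamide nitrogen gives a far larger rise than the cyano-bearing aryl did (a 37-fold higher number from compound 1 to compound 3 (1.57 log units; beyond the scatter)), so the cost of an aryl group at this position is not a single fixed amount. Nitro in place of cyano on an aromatic carbon, with all else kept, gives a separate rise beyond the scatter (a 7.9-fold higher number from compound 2 to compound 3 (0.90 log units; beyond the scatter)), which shows that the group carried on the ring matters in its own right. No measurement at hand accounts for this difference.

Open, on these data alone, is how an unsubstituted phenyl, or a methoxy or amino group on the same ring, would compare with the cyano and nitro pair. Also open, as far as these compounds go, is whether a longer alkyl chain such as propyl would hold the number of compound 1 56.2 nM or move it.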